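Furan-2-yl in place of methyl on a carbonyl carbon

A few compounds are considered here, and "the series" means these few. Any claim that something is new, unique, unknown or untested is made for them only; others in the source may bear on it.

Among the measured compounds shown here, in a functional assay on KB cells (Homo sapiens) for cytotoxicity (on this read-out lower numbers stand for stronger inhibition and higher numbers for weaker inhibition), compound 3 `COc1ccc(S(=O)(=O)N2CCc3cccc(NC(C)=O)c32)cc1` gives 90 nM and so has the highest number of the three compounds measured so far. Compound 1 `COc1ccc(S(=O)(=O)N2CCc3cccc(NC(=O)c4cccs4)c32)cc1` gives 43 nM with thiophen-2-yl on the carbonyl carbon, and compound 2 `COc1ccc(S(=O)(=O)N2CCc3cccc(NC(=O)c4ccncc4)c32)cc1` gives 8.9 nM with pyridin-4-yl there. Compound 4 `COc1ccc(S(=O)(=O)N2CCc3cccc(NC(=O)c4ccco4)c32)cc1` has not been measured yet. It carries furan-2-yl in place of methyl on a carbonyl carbon, and the difference counts as furan-2-yl in place of methyl on a carbonyl carbon in full.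

For the measured compounds named here, two measured steps bear on this change, and both end at the methyl group: a 2.1-fold higher number from compound 1 to compound 3 (0.32 log units; beyond the scatter) and a 10-fold higher number from compound 2 to compound 3 (1.00 log units; beyond the scatter) are what was seen. Replacing methyl with a ring should therefore lower the number. The closer guide is compound 1 at 43 nM as its thiophen-2-yl is also a five-membered aromatic ring, so a modest drop is expected in this assay rather than the larger one. The estimated step is a 3.0-fold lower number from compound 3 to compound 4 (0.48 log units; beyond the scatter) in size. Compound 4 is expected to give about 30 nM with an estimated range from 10 nM to 90 nM as its likely span.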

Compound 4, half-maximal inhibitory concentration: 9.2 nM
Compound 4: middle estimate off by 3.3-fold (0.51 log units), on the high side, and the stated range ends above it.
By their numbers in this assay, from the lowest: compounds 2 and 4 (each within the scatter of the next); then compound 1; then compound 3.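

In this assay, swapping methyl for furan-2-yl on the carbonyl carbon gives a 9.8-fold lower number from compound 3 to compound 4 (0.99 log units; beyond the scatter), and the furan-2-yl and pyridin-4-yl compounds cannot be told apart, with a 1.0-fold higher number from compound 2 to compound 4 (0.01 log units; within the scatter), so a five-membered aromatic ring can do as well here as pyridin-4-yl. Sharing a five-membered aromatic ring does not guarantee the same result, since replacing thiophen-2-yl with furan-2-yl gives a 4.7-fold lower number from compound 1 to compound 4 (0.67 log units; beyond the scatter). No measurement shown explains why these two rings differ.

Going by these compounds, it remains open whether furan-3-yl, attached through a different ring carbon, would match furan-2-yl. The same question stands for a non-aromatic piperidine ring, a longer propyl chain or a carboxylic acid-bearing group on the carbonyl carbon.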